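The source may report more compounds than this note shows. Statements on the series, on what has been measured and on what is new or still open speak of the compounds shown alone.

Among the measured compounds shown here, compound 1 `COc1ccc(-c2ccc3c(NCCCNCc4cccc(OC)c4O)ccnc3c2)cc1` is one of two compounds measured in a physicochemical assay for acid dissociation; in this assay compound 1 gives 9.47, and compound 2 `COc1cccc(CNCCCNc2ccnc3cc(Oc4cccc(N(C)C)c4)ccc23)c1O` gives 9.28. For the measured compounds named here, the only measured step, a number 0.19 log units lower from compound 1 to compound 2 (within the scatter), concerns a group on an aromatic carbon of the core. Compound 3 `COc1ccc(-c2ccc3c(NCCCNCc4cc(F)ccc4OC)ccnc3c2)cc1` differs from compound 1 elsewhere: 5-fluoro-2-methoxyphenyl in place of 2-hydroxy-3-methoxyphenyl on a saturated chain carbon bound to an amine nitrogen. Going by the values given here, no measured step touches this part of the molecule, so the expectation rests on the values of compounds 1 and 2 alone; a step of a number 0.27 log units lower from compound 1 to compound 3 (within the scatter) is expected, not clearly beyond the scatter. Compound 3 is therefore estimated at 9.2, between 8.6 and 9.8.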

Compound 3, acid dissociation constant: 9.47
Estimate against measurement, compound 3: 0.27 log units below, within the range that was stated.
By their numbers in this assay, from the lowest: compounds 2, 1 and 3 (each within the scatter of the next).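

In this assay, among the compounds shown here, the step to 5-fluoro-2-methoxyphenyl in place of 2-hydroxy-3-methoxyphenyl on a saturated chain carbon bound to an amine nitrogen is no change at the digits printed from compound 1 to compound 3 (within the scatter) and is the only reading at this position. The exchange takes away the hydrogen-bond donor of the leaving group and brings in a fluorine, yet the number stays within the scatter. Nothing shown accounts for this result. From the compounds shown here alone, whether a carboxylic acid or an amine in place of the 5-fluoro-2-methoxyphenyl group would move the number remains open. So does the reading for a longer chain.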